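The source may report more compounds than this note shows. Statements on the series, on what has been measured and on what is new or still open speak of the compounds shown alone.

Three compounds share one core and differ only in the group carried on the amide-type nitrogen of the five-membered ring. Compound 1 `O=C(O)c1cc(-c2cccc(COc3ccc4c(c3)CN(Cc3ccc(C(F)(F)F)cc3)C4=O)c2)ccc1Cl` carries a 4-(trifluoromethyl)benzyl group there and, in an assay on HEK293 cells for positive allosteric modulation of metabotropic glutamate receptor 2 (Rattus norvegicus), read by thallium flux (a higher number here means that more compound is needed for the effect, a lower number that less compound is needed), compound 1 gives 350 nM. Compound 2 `CC(C)N1Cc2cc(OCc3cccc(-c4ccc(Cl)c(C(=O)O)c4)c3)ccc2C1=O`, with an isopropyl group, gives 70 nM in this assay, and compound 3 `CC(C)CN1Cc2cc(OCc3cccc(-c4ccc(Cl)c(C(=O)O)c4)c3)ccc2C1=O`, with an isobutyl group, gives 100 nM. The change from the larger aromatic group to a small saturated one gave a 5.0-fold lower number from compound 1 to compound 2 (0.70 log units; beyond the scatter) and a 3.5-fold lower number from compound 1 to compound 3 (0.54 log units; beyond the scatter), while between the two small groups the difference was only a 1.4-fold higher number from compound 2 to compound 3 (0.15 log units; within the scatter). Compound 3 therefore stands second among the three, close to compound 2 and well apart from compound 1.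

Compound 4 `O=C(O)c1cc(-c2cccc(COc3ccc4c(c3)CN(C3CCCCC3)C4=O)c2)ccc1Cl` is the next member of this set. Its difference from compound 3 is cyclohexyl in place of isobutyl on an amide-type nitrogen in a ring. The measured steps suggest that the identity of a small saturated group at this position matters little, since compound 2 and compound 3 lie within the scatter of each other, whereas the large aromatic group of compound 1 was clearly worse. Compound 4 is thus expected to stay near compound 3, with an estimated step of a 1.3-fold lower number from compound 3 to compound 4 (0.10 log units; within the scatter). For compound 4 the estimated value in this assay is 80 nM, with a range from 30 nM to 250 nM.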

Compound 4, half-maximal effective concentration: 270 nM
Estimate against measurement, compound 4: 3.4-fold (0.53 log units) below, and the stated range ends below it.
By their numbers in this assay, from the lowest: compounds 2 and 3 (each within the scatter of the next); then compounds 4 and 1 (each within the scatter of the next).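

The saturated group on the amide-type nitrogen turns out not to be interchangeable: in this assay, there is a 2.7-fold higher number from compound 3 to compound 4 (0.43 log units; beyond the scatter) and a 3.9-fold higher number from compound 2 to compound 4 (0.59 log units; beyond the scatter), so being small and saturated is not enough to keep the number low. The cyclohexyl group also lands level with the aromatic group, with a 1.3-fold lower number from compound 1 to compound 4 (0.11 log units; within the scatter), which means that an aromatic ring is not needed for a number in this higher range, and that among these four compounds the lower numbers belong only to isopropyl and isobutyl, the two groups without a ring. No measurement available here explains why this change raises the number.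

The compounds shown leave open whether the ring itself or the larger count of carbons matters, since cyclohexyl differs from isobutyl in both. A straight hexyl chain, with the same carbon count but no ring, and a cyclopropyl or cyclobutyl group, with a ring but fewer carbons, would pull these two apart.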